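A bromophenyl swap on the benzyl arm of compound 2

This account rests on a few compounds, and the source may have more. Where it says the series, first, only, none or still open, it means among the compounds named here.

Three compounds sharing one core were tested in an assay on HEK293 cells for inhibition of Steryl-sulfatase (Homo sapiens), tested at 0.1 uM; a higher number here means a stronger effect of the compound at the concentration tested, a lower number a weaker effect. Compound 1 `NS(=O)(=O)Oc1ccc2c(c1)CN(C(=O)c1cccc(N3CCN(c4ncccn4)CC3)c1)CC2` gives 1.6%. Compound 2 `CCN(Cc1ccc(Br)cc1)c1cccc(C(=O)N2CCc3ccc(OS(N)(=O)=O)cc3C2)c1` gives 24.2%, and compound 3 `CN(C)CCCN(Cc1ccccc1)c1cccc(C(=O)N2CCc3ccc(OS(N)(=O)=O)cc3C2)c1` gives 23.8%. Compound 2 holds the highest of the three numbers; compound 3 sits within the scatter of it, so no order can be read between those two, while compound 1 lies beyond the scatter below compound 2.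

Compound 4 `CCN(Cc1cccc(Br)c1)c1cccc(C(=O)N2CCc3ccc(OS(N)(=O)=O)cc3C2)c1` has not been measured. It differs from compound 2 by 3-bromophenyl in place of 4-bromophenyl on a saturated chain carbon bound to a nitrogen on an aromatic ring. Among the compounds with values here, the two have the same atoms, joined differently, and no measured pair in this set shows what such a change does in this assay. Within the data shown here, the only guidance is that compound 2 and compound 3, which carry different benzyl arms on the same nitrogen, give readings within the scatter of each other, whereas compound 1, which carries no benzyl arm, falls well below.

On that basis compound 4 is expected to stay close to compound 2, with the step from compound 2 to compound 4 estimated as a number 3.2 percentage points lower from compound 2 to compound 4 (within the scatter), a change of no size beyond the scatter. Compound 4 is therefore estimated at 21%, with a range from 9% to 33%.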

Compound 4, a percentage reported as inhibition, at one concentration (the size of the read-out at that concentration, not a potency): 20.9%
Compound 4: middle estimate off by 0.1 percentage points, on the high side; the measured number falls inside the stated range.
By their numbers in this assay, from the lowest: compound 1; then compounds 4, 3 and 2 (each within the scatter of the next).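

In this assay, 3-bromophenyl in place of 4-bromophenyl on a saturated chain carbon bound to a nitrogen on an aromatic ring gives a number 3.3 percentage points lower from compound 2 to compound 4 (within the scatter), so the readings of these two isomers cannot be told apart. Within the data shown here, this is the first pair in the set that differs in one place, and it gives a direct reading at the benzyl arm that the earlier compounds, each differing from the others in more than one place, could not give: with the ethyl group, the amide and the shared core held fixed, this relocation of the bromine leaves no effect that stands clear of the scatter. No accompanying measurement bears on this result, and the pair offers no explanation for it.

The compounds shown leave open whether the bromine contributes to the reading at all, as a plain phenyl on the same arm, with the ethyl group kept, would be needed to show that. They also leave open what a chlorine, a methoxy group or a carboxylic acid on that phenyl ring would do, or a propyl chain in place of the ethyl group.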